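Swapping the ring on the carbonyl: chloro out, methyl in

A few compounds are considered here, and "the series" means these few. Any claim that something is new, unique, unknown or untested is made for them only; others in the source may bear on it.

Of the compounds shown here, three built on one shared core have been tested in a functional assay on B16-F10 cells (Mus musculus) for antiproliferative activity, read by MTT assay, with a stated time of 48 h; a higher number here means a weaker inhibitor, a lower number a stronger inhibitor. Compound 1 `COc1ccc(/C=C/c2cc(OC)cc(OC)c2/C=C/C(=O)c2ccccc2)cc1` gives 3.7 ug/mL. Compound 2 `COc1ccc(/C=C/c2cc(OC)cc(OC)c2/C=C/C(=O)c2ccc(C(F)(F)F)cc2)cc1` carries a trifluoromethyl in place of hydrogen on an aromatic carbon and gives 4.3 ug/mL, a move of a 1.2-fold higher number from compound 1 to compound 2 (0.07 log units; within the scatter). Compound 3 `COc1ccc(/C=C/c2cc(OC)cc(OC)c2/C=C/C(=O)c2cccc(Cl)c2)cc1` carries a chloro in place of hydrogen on an aromatic carbon and gives 3.3 ug/mL, so that a 1.1-fold lower number from compound 1 to compound 3 (0.05 log units; within the scatter) and a 1.3-fold lower number from compound 2 to compound 3 (0.11 log units; within the scatter). Compound 3 thus holds the lowest of the three numbers, yet every step that reaches it lies within the scatter, so no real ordering among the three compounds can be drawn.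

Compound 4 `COc1ccc(/C=C/c2cc(OC)cc(OC)c2/C=C/C(=O)c2ccccc2C)cc1` is the next structure. It differs from compound 3 in one place: 2-methylphenyl in place of 3-chlorophenyl on a carbonyl carbon. The three measured steps all concern substituents on the ring attached to the carbonyl, and none of them moves the number beyond the scatter. For compound 4 the expected step is therefore a 1.2-fold higher number from compound 3 to compound 4 (0.06 log units; within the scatter), that is, nothing beyond the scatter. Compound 4 is expected to give about 3.8 ug/mL in this assay, within a range from 2 ug/mL to 7.5 ug/mL.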

Compound 4, half-maximal inhibitory concentration: 6.1 ug/mL
Beside the measured number, compound 4's estimate is 1.6-fold (0.21 log units) below it; the range from low to high includes it.
By their numbers in this assay, from the lowest: compounds 3, 1, 2 and 4 (each within the scatter of the next).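

Placing 2-methylphenyl on the carbonyl carbon gives the largest steps seen so far in this assay, namely a 1.8-fold higher number from compound 3 to compound 4 (0.27 log units; within the scatter) and a 1.6-fold higher number from compound 1 to compound 4 (0.22 log units; within the scatter) as well as a 1.4-fold higher number from compound 2 to compound 4 (0.15 log units; within the scatter). Even so, all three stay within the scatter, so hydrogen, trifluoromethyl, chloro and methyl on this ring have still produced no real difference among the four compounds, and the new compound does not alter that picture. Nothing available here gives a measured property that could account for the size of these steps.

The change from 3-chlorophenyl to 2-methylphenyl alters both the group and its place on the ring, so the compounds shown cannot separate the effect of one from the other, and they do not tell whether a methyl or a chloro would read the same if only its place changed. Also open, going by these compounds, is whether a group of another kind on this ring, such as an amine or a carboxylic acid, would move the number beyond the scatter in this assay.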